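A few compounds are considered here, and "the series" means these few. Any claim that something is new, unique, unknown or untested is made for them only; others in the source may bear on it.

Compound 1 `COc1ccccc1/C=C1\NS(=O)(=O)c2ccccc2C1=O` and compound 2 `COc1ccc(/C=C2\NS(=O)(=O)c3ccccc3C2=O)cc1` share one core and differ only in where a methoxy sits on the outer ring. In an assay for inhibition of alkaline phosphatase, tissue-nonspecific isozyme (Homo sapiens), read by spectrophotometry, with stated times of 10 min and 20 min (on this read-out higher numbers stand for weaker inhibition and lower numbers for stronger inhibition), compound 1 gives 2590 nM, the lower of the two numbers, and compound 2 gives 4040 nM, which lies within the usual scatter of that figure. Compound 3 `O=C1/C(=C/c2ccccc2Br)NS(=O)(=O)c2ccccc21` is built from compound 1 by a single change: bromo in place of methoxy on an aromatic carbon. Among the compounds with values here, no measured pair shows what such a swap does here, so the expected step from compound 1 to compound 3 in this assay is a 1.3-fold lower number from compound 1 to compound 3 (0.11 log units; within the scatter), small and not clearly beyond the scatter. Compound 3 is accordingly estimated at 2000 nM, within a range of 600 nM to 6500 nM.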

Compound 3, half-maximal inhibitory concentration: > 200000 nM
Compound 3 gave a limit, no number (the forecaster's own chance of this, stated with the estimate: 5%); middle value at least 100-fold (2.00 log units) from the limit.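

Replacing methoxy with bromo on an aromatic carbon, ortho to a large group, is far from a neutral swap in this assay, giving an at least 77-fold higher number from compound 1 to compound 3 (1.88 log units; beyond the scatter). For compound 3 the read-out is a limit, not a number: the limit of > 200000 nM in this assay, at which 1 of the 3 values shown sits. The earlier compounds shown here only hinted at how much this place matters, whereas here a single substituent change separates a measurable number from a limit.

As far as these compounds go, how far compound 3 lies past its limit remains open. So does whether an amine, a hydroxy group or a longer chain such as ethoxy would behave like methoxy or like bromo at this place.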